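Hydroxyl position on the sulfonyl aryl: compound 1 to compound 4

The source may hold more compounds than are shown below. What is called first, only, known or untested is meant among the compounds shown, and "the series" means these compounds.

Compound 1 `O=S(=O)(Nc1ccc2oc(-c3ccccc3)nc2c1)c1ccccc1O` is measured in an ADME assay on HEK293 cells (Homo sapiens) for cytotoxicity, read by resazurin assay, with a stated time of 48 h (a higher number here means that more compound is tolerated, a lower number that less compound is tolerated), at 33000 nM. Compound 3 `O=S(=O)(Nc1ccc(-c2nc3ccccc3o2)cc1)c1ccc(Cl)c(C(F)(F)F)c1` gives 69000 nM in this assay. Compound 2 `O=S(=O)(Nc1ccc(-c2nc3ccccc3o2)cc1)c1ccc(Cl)s1` reaches only a limit of this assay, > 100000 nM, so no number is known for it (the limit of > 100000 nM in this assay, at which 1 of the 3 values shown sits). Going by the values given here, compound 1 thus holds the lowest of the two numbers known, with compound 3 above it beyond the scatter. The unmeasured compound 4 `O=S(=O)(Nc1ccc2oc(-c3ccccc3)nc2c1)c1cccc(O)c1` keeps the same atoms, joined differently: 3-hydroxyphenyl in place of 2-hydroxyphenyl on a sulfonyl sulfur. Among the compounds with values here, no step between measured compounds is recorded, and the change moves one hydroxyl on the same ring only. The step from compound 1 to compound 4 is expected to be small, within the scatter or just beyond it, if anything toward a higher number a 1.2-fold higher number from compound 1 to compound 4 (0.08 log units; within the scatter). Compound 4 is therefore estimated at 40000 nM, with a range from 15000 nM to 110000 nM.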

Compound 4, half-maximal cytotoxic concentration: > 100000 nM
Compound 4 ended at the assay's limit; the forecaster's own chance of this, stated with the estimate: 20%; middle value at least 2.5-fold (0.39 log units) from the limit.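

This is the series' first step between measured compounds, and it shows that this position is sensitive to where the hydroxyl sits: 3-hydroxyphenyl in place of 2-hydroxyphenyl on a sulfonyl sulfur gives an at least 3.0-fold higher number from compound 1 to compound 4 (0.48 log units; beyond the scatter) in this assay. The atoms stay the same, so the connectivity of the ring alone accounts for the step. Its full size stays unknown, since compound 4 stands at a limit of the assay: the limit of > 100000 nM in this assay, at which 2 of the 4 values shown sit.

Open: whether a methoxy group or an amine on this ring would follow the hydroxyl, and whether the step carries over to other cores.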